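Adding a Methoxy Group to Triazole Cytotoxicity Compounds

A few compounds are considered here, and "the series" means these few. Any claim that something is new, unique, unknown or untested is made for them only; others in the source may bear on it.

Compound 1 `COc1cc(OC)cc(-n2cc(-c3ccc(OC)c(O)c3)nn2)c1` was tested in a functional assay on MDA-MB-231 cells (Homo sapiens) for cytotoxicity, read by MTT assay; a lower number here means a stronger inhibitor, a higher number a weaker inhibitor. In this assay compound 1 gives only a limit of the assay, > 10000 nM. Compound 2 `COc1ccc(-c2cn(-c3cc(OC)c(OC)c(OC)c3)nn2)cc1O` differs from compound 1 by methoxy in place of hydrogen on an aromatic carbon. In this assay compound 2 likewise gives a limit, > 10000 nM. The step between them, a step that the two limits leave unreadable from compound 1 to compound 2, cannot be sized because the limit of > 10000 nM in this assay, at which 3 of the 3 values shown sit, leaves no number on either side. Compound 3 `COc1cc(OC)cc(-c2cn(-c3ccc(Oc4ccccc4)cc3)nn2)c1` carries a different core; how it differs from the core of compound 1 is not broken down here. In this assay compound 3 also gives a limit, > 10000 nM. The unmeasured compound 4 `COc1cc(-c2cn(-c3ccc(Oc4ccccc4)cc3)nn2)cc(OC)c1OC` differs from compound 3 by methoxy in place of hydrogen on an aromatic carbon, the same change as that from compound 1 to compound 2, at a place described in identical words. Within the data shown here, since every value so far is a limit, the expected step that the limit leaves unreadable from compound 3 to compound 4 rests only on the likelihood that compound 4 stays where its neighbours sit. Compound 4 is therefore estimated at 15000 nM, most probably reported as a limit again.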

Compound 4, half-maximal inhibitory concentration: 10000 nM
Beside the measured number, compound 4's estimate is 1.5-fold (0.18 log units) above it, and the stated range covers the measured number.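

On the core of compound 3, methoxy in place of hydrogen on an aromatic carbon gives a number no higher from compound 3 to compound 4 (the limit leaves the size open) in this assay. Neither this step nor the same change on the core of compound 1 can be sized, because the values on both cores rest on the assay limit: the limit of > 10000 nM in this assay, at which 3 of the 4 values shown sit. Among these compounds, the result shows only that neither methoxy compound reaches a low number on its core; it does not show whether the change acts alike on the two cores, by the same amount or even in the same direction.

The compounds shown leave open whether another group on this aromatic carbon, such as an amine, a carboxylic acid or a longer chain, would bring the values down into a readable range. They also leave open what size the methoxy change would have on a core whose values lie well clear of the limit.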